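Carboxy against morpholinylcarbonyl in the growth assay

The source may report more compounds than this note shows. Statements on the series, on what has been measured and on what is new or still open speak of the compounds shown alone.

Measured compounds:
compound 1 `O=C(O)/C=C/c1ccncc1-c1ccc2ccccc2c1` — > 30000 nM
compound 2 `Cn1ccc2cc(-c3cnccc3/C=C/C(=O)N3CCOCC3)ccc21` — "not determined" (no result reported)
compound 3 `O=C(/C=C/c1ccncc1-c1ccc2ccccc2c1)N1CCOCC1` — 6040 nM

In a functional assay on HCT-116 cells (Homo sapiens) for inhibition, read by MTT assay, with a stated time of 72 h (on this read-out higher numbers stand for weaker inhibition of growth and lower numbers for stronger inhibition of growth), compound 3 gives 6040 nM. For compound 1 only a limit is recorded, > 30000 nM, so no number is known there (the limit of > 30000 nM in this assay, at which 1 of the 3 values shown sits). The change is hydroxy in place of morpholin-4-yl on a carbonyl carbon, and it produced an at least 4.9-fold higher number from compound 3 to compound 1 (0.69 log units; beyond the scatter). Compound 2 carries a different core; how the cores of compound 2 and compound 3 differ is not broken down here, and for compound 2 this assay reports "not determined" (no result reported). Compound 4 `Cn1ccc2cc(-c3cnccc3/C=C/C(=O)O)ccc21` is not yet measured. It arises from compound 2 by the same change, (hydroxy in place of morpholin-4-yl on a carbonyl carbon), at the same place. The step from compound 2 to compound 4 in this assay is expected to be of the same kind and at least as large as that from compound 3 to compound 1, resting on an at least 4.9-fold higher number from compound 3 to compound 1 (0.69 log units; beyond the scatter) alone, with the second core unmeasured. Compound 4 is therefore estimated at 40000 nM, between 10000 nM and 150000 nM, most likely reported as a limit.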

Compound 4, concentration for 50% growth inhibition: 7260 nM
Estimate against measurement, compound 4: 5.5-fold (0.74 log units) above, outside the stated range (below it).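

Compound 2 carries no number in this assay, so the step from it to compound 4 cannot be read. Going by these compounds, whether hydroxy in place of morpholin-4-yl has the same size of effect on the core of compound 4 as on the core of compound 3 stays open.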